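The source may report more compounds than this note shows. Statements on the series, on what has been measured and on what is new or still open speak of the compounds shown alone.

Series notes. In an assay on CHO cells for displacement of a labelled ligand from transient receptor potential cation channel subfamily V member 1 (Rattus norvegicus) (a higher number here means a weaker inhibitor, a lower number a stronger inhibitor), compound 1 `CC(NC(=O)/C=C/c1ccc(C(C)(C)C)cc1)c1ccc(NS(C)(=O)=O)c(F)c1` gives 105 nM. Compound 2 `CC(C(=O)NCc1ccc(Cl)cc1)c1ccc(NS(C)(=O)=O)c(F)c1` gives 1060 nM in this assay, the higher of the two numbers shown, and the gap between compound 2 and compound 1 lies beyond the scatter. Compound 3 `CC(C(=O)NCc1ccc(Br)cc1)c1ccc(NS(C)(=O)=O)c(F)c1` is not yet measured; it differs from compound 2 in one place: bromo in place of chloro on an aromatic carbon. Among the measured compounds shown here, no step between measured compounds bears on this exchange, so the expectation rests on the change alone, and a step of no size beyond the scatter is expected from compound 2 to compound 3, a 1.2-fold lower number from compound 2 to compound 3 (0.10 log units; within the scatter). For compound 3 the estimate in this assay is 850 nM, with a range from 300 nM to 2500 nM.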

Compound 3, inhibition constant: 412 nM
Compound 3: the middle estimate sits 2.1-fold (0.31 log units) above what was measured, within the range that was stated.
By their numbers in this assay, from the lowest: compound 1; then compound 3; then compound 2.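

In this assay, 4-chlorobenzyl to 4-bromobenzyl gives a real change (a 2.6-fold lower number from compound 2 to compound 3 (0.41 log units; beyond the scatter)), so this place on the aromatic ring responds even to an exchange of one halogen for another, with no hydrogen-bond donor, acceptor or net charge changed. This is a single pair, and so shows no trend. Nothing at hand accounts for the step. On these data alone, whether an iodo, methyl or trifluoromethyl group here would give a lower or higher number than bromo stays open, as does whether the exchange would act alike on another core.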